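Piperidine replaces octyl on the decyl chain of compound 2

This account rests on a few compounds, and the source may have more. Where it says the series, first, only, none or still open, it means among the compounds named here.

Measured compounds:
Compound 1, `C=CCn1c(=O)n(C2CN(CCCC)CC(CO)O2)c2nc(N)nc(O)c21`: 52%
Compound 2, `CCCCCCCCCCn1c(=O)n(C2OC(CO)[C@@H](O)[C@H]2O)c2nc(N)nc(O)c21`: 0%

In a functional assay on the whole organism with Mus musculus as the target (on this read-out higher numbers stand for larger maximal responses and lower numbers for smaller maximal responses), compound 2 gives 0%, the lowest of the two numbers shown. Within the data shown here, its nearest neighbour is compound 1, whose maximal response is higher by a margin beyond the scatter, though the two differ in more than one place and no single step between them is given.

Compound 3, `Nc1nc(O)c2c(n1)n(C1OC(CO)[C@@H](O)[C@H]1O)c(=O)n2CCN1CCCCC1`, has not yet been measured. It differs from compound 2 in one place: piperidin-1-yl in place of octyl on a saturated chain carbon, two bonds along the chain from an aromatic nitrogen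

Among the measured compounds shown here, with no measured step between closely related compounds available, the expectation for compound 3 rests on compound 1, which in this assay gives 52% while also carrying a chain nitrogen in a ring. On that basis an upward step a number 30 percentage points higher from compound 2 to compound 3 (beyond the scatter) is expected, beyond the scatter. Compound 3 is therefore estimated at 30%, within 0% to 65%.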

Compound 3, largest response reached (reported as maximal response), in percent of the reference or control that the assay uses: 0%
The estimate for compound 3 lay 30 percentage points above the measured number; the measured number falls inside the stated range.
By their numbers in this assay, from the lowest: compounds 2 and 3 (each within the scatter of the next); then compound 1.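

In this assay, exchanging octyl for piperidin-1-yl on a saturated chain carbon, two bonds along the chain from an aromatic nitrogen, gives no change at the digits printed from compound 2 to compound 3 (within the scatter). At this position, then, replacing the end of the decyl chain to give a 2-(piperidin-1-yl)ethyl group, with its ring and its nitrogen, does not by itself bring a maximal response on this core, and the response of compound 1 cannot be traced to such a ring-bearing chain alone, since compound 1 differs from compound 3 in more than one place. Nothing shown gives a measured reason for this result.

On these data alone, it remains open whether an open-chain amine such as a 2-(diethylamino)ethyl group, or a morpholine ring, at this position would give a response on the core of compound 3. Also open, as far as these compounds go, is which of the several differences in compound 1 goes with its response, such as the allyl group in place of the 2-(piperidin-1-yl)ethyl group.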